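This account rests on a few compounds, and the source may have more. Where it says the series, first, only, none or still open, it means among the compounds named here.

Within the data shown here, compound 3 `COc1ccc(Oc2ccc3c(NCCCNCc4ccco4)ccnc3c2)cc1` sits second highest of the three compounds measured so far in a physicochemical assay for solubility, with a stated time of 18 h, at pH 7.4 (on this read-out higher numbers stand for higher solubility and lower numbers for lower solubility), where compound 3 gives 14500 nM. Compound 2 `COc1ccc(-c2ccc3c(NCCCNCc4ccco4)ccnc3c2)cc1` gives 32000 nM in this assay, and compound 1 `Fc1ccc(Cc2ccc3c(NCCCNCc4ccco4)ccnc3c2)c(Cl)c1` gives 4200 nM.

Compound 4 `Fc1ccc(Cc2ccc3c(NCCCNCc4ccco4)ccnc3c2)cc1` differs from compound 3 in one place: 4-fluorobenzyl in place of 4-methoxyphenoxy on an aromatic carbon. Among the measured compounds shown here, two measured steps bear on this change. Going from the benzyl-bearing compound 1 to compound 3 brought a 3.5-fold higher number from compound 1 to compound 3 (0.54 log units; beyond the scatter), and from compound 1 to compound 2 brought a 7.6-fold higher number from compound 1 to compound 2 (0.88 log units; beyond the scatter), so the benzyl-bearing compound 1 sits lowest of the three in this assay. The step from compound 2 to compound 3, a 2.2-fold lower number from compound 2 to compound 3 (0.34 log units; beyond the scatter), shows the two ether-type and direct-linked groups sit fairly close to each other.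

Compound 4 carries a 4-fluorobenzyl group, which is close to the group in compound 1 but without the chlorine, so a step downward from compound 3 of roughly the size seen from compound 1 to compound 3, reversed, is expected, perhaps a little smaller: a 2.4-fold lower number from compound 3 to compound 4 (0.38 log units; beyond the scatter). The expected value for compound 4 in this assay is therefore 6000 nM, with a likely range from 2000 nM to 18000 nM.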

Compound 4, solubility: 4200 nM
The estimate for compound 4 lay 1.4-fold (0.15 log units) above the measured number; low and high end bracket the measured number.
By their numbers in this assay, from the lowest: compounds 1 and 4 (each within the scatter of the next); then compound 3; then compound 2.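

In this assay, putting hydrogen in place of chloro gives no change at the digits printed from compound 1 to compound 4 (within the scatter) so the low number of compound 1 cannot be pinned on its chloro group. What the two low compounds share at this position is a fluorobenzyl group: 4-fluorobenzyl in place of 4-methoxyphenoxy brings a 3.5-fold lower number from compound 3 to compound 4 (0.54 log units; beyond the scatter) and 4-fluorobenzyl in place of 4-methoxyphenyl brings a 7.6-fold lower number from compound 2 to compound 4 (0.88 log units; beyond the scatter) so the same steps seen earlier from compound 1 now appear without any chloro group involved. Nothing measured here explains why the 4-fluorobenzyl compounds give the lower numbers.

From the compounds shown here alone, it remains open whether those lower numbers go with the carbon link of the benzyl group or with the fluoro group on its ring, a question that a 4-methoxybenzyl group, which would pair that link with the methoxy of compound 2 and compound 3, could help to settle. Also open, going by these compounds, is how groups of a quite different kind, such as an amine or a carboxylic acid, would behave at this same position on the shared core.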